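A Phenyl Amide Tried Against Two Inactive Alkyl Amides

This account rests on a few compounds, and the source may have more. Where it says the series, first, only, none or still open, it means among the compounds named here.

Compound 2 `C=CC1=C(C(=O)NCC(C)C)C(c2ccc(Cl)c(Cl)c2)OC1` carries an isobutyl group on its amide nitrogen. In a functional assay on SW480 cells (Homo sapiens) for cytotoxicity, read by MTT assay, with a stated time of 24 h (a higher number here means a weaker inhibitor, a lower number a stronger inhibitor), compound 2 gives > 100000 nM, which is a limit of the assay rather than a measured number. Its neighbour compound 1 `C=CC1=C(C(=O)NCCC)C(c2ccc(Cl)c(Cl)c2)OC1` has a propyl group in that place. In this assay compound 1 gives > 100000 nM, again a limit of the assay. The step that the two limits leave unreadable from compound 1 to compound 2 therefore cannot be read, since the limit of > 100000 nM in this assay, at which 2 of the 2 values shown sit, covers both values. Compound 3 `C=CC1=C(C(=O)Nc2ccccc2)C(c2ccc(Cl)c(Cl)c2)OC1` keeps the shared core and changes only the amide group: phenyl in place of isobutyl on an amide-type nitrogen. Within the data shown here, no measured step involves a phenyl group, so the only guide is that compound 1 and compound 2 both sit at the limit of this assay. Compound 3 is therefore expected to sit close to that limit as well, so the expected step of a number no higher from compound 2 to compound 3 (the limit leaves the size open) carries little information. The estimate for compound 3 in this assay is 100000 nM, expected to fall between 30000 nM and 300000 nM, and most likely reported once more only as a limit.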

Compound 3, half-maximal inhibitory concentration: > 100000 nM
Compound 3 gave a limit, no number; the forecaster's own chance of this, stated with the estimate: 75%; the middle value sits exactly at the limit.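

In this assay the steps among compound 1, compound 2 and compound 3 cannot be read, since all three give a limit of the assay rather than a number: the limit of > 100000 nM in this assay, at which 3 of the 3 values shown sit.

In this assay the compounds shown leave open whether any amide group on the shared core gives a measurable value, and how propyl, isobutyl and phenyl truly compare.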